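The source may report more compounds than this note shows. Statements on the series, on what has been measured and on what is new or still open speak of the compounds shown alone.

In an ADME assay on the whole organism (Mus musculus, strain CD-1) for pharmacokinetics, at a dose of 10 mg/kg by the oral route (on this read-out higher numbers stand for higher exposure at the dose given and lower numbers for lower exposure), compound 1 (`CCOc1cc([C@](O)(CCN(C)C)[C@@H](c2cc3cc(Br)ccc3nc2OC)c2cccc(OC)c2F)cc(OC)n1`) gives 4000 ng.h/mL while compound 2 (`COc1cc([C@](O)(CCN(C)C)[C@@H](c2cc3cc(Br)ccc3nc2OC)c2ccnc(OC)c2OC)cc(OC(C)C)n1`) gives 5600 ng.h/mL and compound 3 (`COc1cc([C@](O)(CCN(C)C)[C@@H](c2cc3cc(C#N)ccc3nc2OC)c2cccc(C)c2F)cc(OC(F)F)n1`) gives 8600 ng.h/mL as its measured exposure. Compound 2 stands within the scatter of both compound 1 and compound 3. Compound 4 (`COc1cc([C@](O)(CCN(C)C)[C@@H](c2cc3cc(Br)ccc3nc2OC)c2ccnc(OC)c2OC)cc(OC(F)F)n1`) differs from compound 2 in one place (difluoromethyl in place of isopropyl on an oxygen on an aromatic ring) with difluoromethyl in place of isopropyl on an oxygen on an aromatic ring. Among the compounds with values here, no measured pair isolates this change. Going by these compounds, compound 3 also carries difluoromethoxy and gives 8600 ng.h/mL in that form, yet it differs from compound 2 elsewhere too, so no step beyond the scatter is expected in this assay and the direction stays open. The expected move (a 1.1-fold higher number from compound 2 to compound 4 (0.03 log units; within the scatter)) is small. For compound 4 the estimate is 6000 ng.h/mL within an expected range from 2800 ng.h/mL to 12000 ng.h/mL on this read-out.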

Compound 4, area under the concentration-time curve: 9800 ng.h/mL
The estimate for compound 4 lay 1.6-fold (0.21 log units) below the measured number; the measured number falls inside the stated range.
By their numbers in this assay, from the lowest: compounds 1, 2, 3 and 4 (each within the scatter of the next, the first and the last beyond it).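

Within the data shown here, with this pair the isopropoxy to difluoromethoxy exchange is isolated for the first time on the shared core: in this assay it gives a 1.8-fold higher number from compound 2 to compound 4 (0.24 log units; within the scatter) and so does not separate the two groups on this oxygen on an aromatic ring. Exposure at this place therefore tolerates difluoromethyl as well as isopropyl, with three heavy atoms in each. Still open, going by these compounds, is how trifluoromethyl, cyclopropyl or a longer chain such as n-butyl would read on this oxygen, and whether an amine could replace the ether. Nothing available explains the exposure of either compound.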